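Dropping one isopropyl from a trisubstituted aryl enone acid

The compounds below may be only part of what the source reports. "The series", "measured", "known", "first", "only" and "open" are said of these compounds alone.

Measured so far in a functional assay on K562 cells (Homo sapiens) for inhibition, read by MTT assay, with a stated time of 72 h; on this read-out lower numbers stand for stronger inhibition and higher numbers for weaker inhibition:
- compound 1, `Cc1cc(C2CCCCC2)c(C)cc1C(=O)/C=C/C(=O)O`, gives 4240 nM
- compound 2, `CC(C)c1cc(C(C)C)c(C(=O)/C=C/C(=O)O)c(C(C)C)c1`, gives 4670 nM
- compound 3, `O=C(O)/C=C/C(=O)c1ccc(F)cc1`, gives 16900 nM

All three share the same acid-bearing enone chain attached to an aromatic ring; they differ only in what sits on that ring. Compound 2 stands at the second highest of the three numbers. Its nearest neighbour is compound 1, whose value lies within the usual scatter of compound 2, so the two cannot be told apart. Compound 3 lies furthest away and gives a clearly higher number than compound 2, meaning weaker inhibition.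

The new compound 4, `CC(C)c1ccc(C(=O)/C=C/C(=O)O)c(C(C)C)c1`, is compound 2 with one change: hydrogen in place of isopropyl on an aromatic carbon. The isopropyl that leaves is the one ortho to the (2-carboxyethenyl)carbonyl group; the two isopropyls meta to that position remain. Within the data shown here, no pair of measured compounds differs in exactly this way, so the effect must be guessed from the overall picture: the least substituted ring (compound 3) gives the highest number, while the heavily substituted rings of compounds 1 and 2 give lower numbers.

For compound 4 the expected step is therefore a 1.5-fold higher number from compound 2 to compound 4 (0.18 log units; within the scatter), a modest rise that may not exceed the scatter. Compound 4 is estimated at 7000 nM, with a range from 3000 nM to 16000 nM.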

Compound 4, half-maximal inhibitory concentration: 4680 nM
The estimate for compound 4 lay 1.5-fold (0.17 log units) above the measured number; the measured number falls inside the stated range.
By their numbers in this assay, from the lowest: compounds 1, 2 and 4 (each within the scatter of the next); then compound 3.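

In this assay putting hydrogen in place of isopropyl on this aromatic carbon, ortho to the (2-carboxyethenyl)carbonyl group, gives a 1.0-fold higher number from compound 2 to compound 4 (0.00 log units; within the scatter) and so leaves compound 2 and compound 4 indistinguishable. Among these compounds, this is the first direct comparison at this position, and it shows that, on this read-out, the isopropyl there can be exchanged for hydrogen without a detectable difference, so this group is not required for the inhibition seen with compound 2. Nothing available here explains why the two compounds match.

The comparison covers only hydrogen and isopropyl at this one position, so a group of another kind there, such as an amine, a methoxy group or a longer chain, could still behave differently. The two isopropyl groups that remain in compound 4 also stay untested, as no compound shown differs from compound 4 at either of those places alone, and their own contribution to the value of compound 4 cannot be read from these data.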